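A few compounds are considered here, and "the series" means these few. Any claim that something is new, unique, unknown or untested is made for them only; others in the source may bear on it.

Working notes on a chlorinated purine series tested in a functional assay on HOP-92 cells (Homo sapiens) for cytotoxicity, read by sulforhodamine B assay, with a stated time of 48 h; a higher number here means a weaker inhibitor of growth, a lower number a stronger inhibitor of growth.

Compound 1 `ClCc1ccccc1Cn1cnc2c(Cl)nc(Cl)nc21` gives 970 nM in this assay. Compound 2 `ClCc1cccc(Cn2cnc3c(Cl)nc(Cl)nc32)c1` gives 3630 nM; its atoms are the same as those of compound 1, joined differently, and the difference between the two cores is not broken down here. Compound 3 `Nc1nc(Cl)c2ncn(Cc3ccccc3CCl)c2n1` gives 30900 nM. The change from compound 1 to compound 3 is amino in place of chloro on an aromatic carbon, and the step it made in this assay is a 32-fold higher number from compound 1 to compound 3 (1.50 log units; beyond the scatter). Among the three measured compounds, compound 2 stands second, with the values of compound 1 and compound 3 on either side of it.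

Compound 4 `Nc1nc(Cl)c2ncn(Cc3cccc(CCl)c3)c2n1` is not yet measured. Its change from compound 2 is amino in place of chloro on an aromatic carbon, the same change as from compound 1 to compound 3, made on the core of compound 2 instead of that of compound 1. The step of a 25-fold higher number from compound 2 to compound 4 (1.39 log units; beyond the scatter) is expected to be of a size like a 32-fold higher number from compound 1 to compound 3 (1.50 log units; beyond the scatter), resting on that single measured pair. Compound 4 is therefore estimated at 90000 nM in this assay, with a plausible range from 25000 nM to 300000 nM.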

Compound 4, concentration for total growth inhibition: 38000 nM
Beside the measured number, compound 4's estimate is 2.4-fold (0.37 log units) above it; measured number inside the range.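

In this assay, amino in place of chloro on an aromatic carbon again goes with a weaker inhibitor of growth on a second core, a 10-fold higher number from compound 2 to compound 4 (1.02 log units; beyond the scatter), so the direction of the step is shared by the core of compound 1 and the core of compound 2. The size of the step does not carry over unchanged, and the two steps differ: the same change on two cores in this assay, a 32-fold higher number (1.50 log units; beyond the scatter) from compound 1 to compound 3 and a 10-fold higher number (1.02 log units; beyond the scatter) from compound 2 to compound 4, 3.0-fold (0.48 log units) apart, beyond the scatter of two such steps These two pairs show that the direction held on both cores shown, but they do not explain the gap in size, and two cores are too few to set a rule for the whole series.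

Still open, as far as these compounds go, is what a group other than amino would do at the same place, between two ring nitrogen atoms, for example a methylamino or a methoxy group in place of the chloro. Also open, from the compounds shown here alone, is whether the direction of the step would hold on a core carrying a longer chain, such as chloroethyl, in place of the chloromethyl group.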